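Carbamate and ester prodrug tails on a nucleoside core

A few compounds are considered here, and "the series" means these few. Any claim that something is new, unique, unknown or untested is made for them only; others in the source may bear on it.

Measured compounds:
- Compound 1, `Cc1cn(C2CC(N=[N+]=[N-])C(COC(=O)NCCCO)O2)c(=O)[nH]c1=O`: in a functional assay on MT4 cells (Homo sapiens) for cytotoxicity (on this read-out lower numbers stand for higher toxicity in this test and higher numbers for lower toxicity in this test), compound 1 gives only a limit of the assay, > 50000 nM.
- Compound 2, `Cc1cn(C2CC(N=[N+]=[N-])C(COC(=O)OCCCCCCO)O2)c(=O)[nH]c1=O`: in this assay compound 2 also gives only a limit, > 50000 nM.
- Compound 3, `Cc1cn(C2CC(N=[N+]=[N-])C(COC(=O)CCCC(=O)O)O2)c(=O)[nH]c1=O`: in this assay compound 3 gives only a limit as well, > 50000 nM.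

Compound 3 thus stands at the same limit as its two companions, so no ordering among the three can be read from these numbers. Compound 4, `Cc1cn(C2CC(N=[N+]=[N-])C(COC(=O)OCCCN)O2)c(=O)[nH]c1=O`, differs from compound 3 in one place: 3-aminopropoxy in place of 3-carboxypropyl on a carbonyl carbon. For the measured compounds named here, the steps that bear on this change are a step that the two limits leave unreadable from compound 1 to compound 3, a step that the two limits leave unreadable from compound 2 to compound 3 and a step that the two limits leave unreadable from compound 1 to compound 2; none of them can be sized, because of the limit of > 50000 nM in this assay, at which 3 of the 3 values shown sit. With every measured value at that limit and the tail again an uncharged chain carrying one hydrogen-bond donor, the expectation for compound 4 is a step that the limit leaves unreadable from compound 3 to compound 4, none beyond the scatter. Compound 4 is therefore estimated at 100000 nM, within a range of 40000 nM to 300000 nM, most likely reported again as a limit in this assay.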

Compound 4, half-maximal cytotoxic concentration: > 50000 nM
Compound 4: only a limit was reported; the forecaster's own chance of this, stated with the estimate: 85%; the middle value is on the limit's open side.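

In this assay compound 4 also gives only a limit of the assay, > 50000 nM. For the compounds shown here, no step linking compound 4 to compound 1, compound 2 or compound 3 can be read, because all four stand at one limit: the limit of > 50000 nM in this assay, at which 4 of the 4 values shown sit. In this assay the compounds shown leave open how far these four tails differ.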